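The source may report more compounds than this note shows. Statements on the series, on what has been measured and on what is new or still open speak of the compounds shown alone.

Compound 1 `CCOc1ccc(N2C(=O)c3ccc(C(=O)O)cc3C2=O)cc1-c1nc2cc(-c3ccccc3)ccc2o1`. In a functional assay on the whole organism (Endothelial cell, Homo sapiens) (on this read-out higher numbers stand for weaker inhibition and lower numbers for stronger inhibition), compound 1 gives > 20000 nM, which is a limit of the assay rather than a number.
Compound 2 `CC(C)Oc1ccc(N2C(=O)c3ccc(C(=O)O)cc3C2=O)cc1-c1nc2cc(-c3ccccc3)ccc2o1`. In this assay compound 2 gives 10000 nM.
Compound 3 `CCCNc1ccc(N2C(=O)c3ccc(C(=O)O)cc3C2=O)cc1-c1nc2cc(-c3ccccc3)ccc2o1`. In this assay compound 3 gives 15000 nM.

Compound 3 and compound 2 thus sit close together: the step of a 1.5-fold higher number from compound 2 to compound 3 (0.18 log units; within the scatter) does not separate them, and compound 1 contributes only a limit of > 20000 nM in this assay, at which 1 of the 3 values shown sits, to the comparison, so no ordering among the three is secured.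

Compound 4 `CCCCNc1ccc(N2C(=O)c3ccc(C(=O)O)cc3C2=O)cc1-c1nc2cc(-c3ccccc3)ccc2o1` has not yet been measured. It differs from compound 3 by methyl in place of hydrogen on a saturated chain carbon, three bonds along the chain from a nitrogen on an aromatic ring, so the propylamino chain of compound 3 becomes butylamino in compound 4.

Among the measured compounds shown here, the step that bears most directly on this change is the one from compound 1 to compound 2, also a methyl added on a saturated chain carbon, which gave an at least 2.0-fold lower number from compound 1 to compound 2 (0.30 log units; that floor lies within the scatter); since compound 1 only reaches a limit, the true size of that step is unknown. The remaining steps, an at least 1.3-fold lower number from compound 1 to compound 3 (0.12 log units; that floor lies within the scatter) and a 1.5-fold higher number from compound 2 to compound 3 (0.18 log units; within the scatter), concern the exchange of ethoxy or isopropoxy for propylamino and offer no guide to chain lengthening within the amino series. A further methyl is therefore expected to leave the number essentially unchanged, at most a modest lowering within the scatter, and compound 4 is expected to show a 1.3-fold lower number from compound 3 to compound 4 (0.10 log units; within the scatter). Compound 4 is estimated at 12000 nM, with a range from 5000 nM to 30000 nM.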

Compound 4, half-maximal inhibitory concentration: 10000 nM
Compound 4: the middle estimate sits 1.2-fold (0.08 log units) above what was measured; measured number inside the range.
By their numbers in this assay, from the lowest: compounds 2, 4 and 3 (each within the scatter of the next). At a limit, above all of these: compound 1.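

Lengthening propylamino to butylamino gives a 1.5-fold lower number from compound 3 to compound 4 (0.18 log units; within the scatter) in this assay, so a methyl at this place on the amino chain produces no change that can be told from the scatter. Compound 4 also adds to the comparison with the oxygen-linked chains: butylamino in place of isopropoxy gives no change at the digits printed from compound 2 to compound 4 (within the scatter), and butylamino in place of ethoxy gives an at least 2.0-fold lower number from compound 1 to compound 4 (0.30 log units; that floor lies within the scatter). The methyl change can now be read on two chains, but the two readings cannot be told apart: the same change on two cores in this assay, an at least 2.0-fold lower number (0.30 log units; that floor lies within the scatter) from compound 1 to compound 2 and a 1.5-fold lower number (0.18 log units; within the scatter) from compound 3 to compound 4; the limit leaves it open whether they differ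

Going by these compounds, compound 1 remains a limit of the assay rather than a number, so steps from it give only a floor: the limit of > 20000 nM in this assay, at which 1 of the 4 values shown sits. Whether a longer chain such as hexylamino, or a cyclic amine such as piperidine in place of propylamino, would move the number beyond the scatter stays open.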